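The source may hold more compounds than are shown below. What is called first, only, known or untested is meant among the compounds shown, and "the series" means these compounds.

Of the compounds shown here, three sharing one core have been tested in a functional assay on HeLa cells (Homo sapiens) for antiproliferative activity, read by sulforhodamine B assay, with a stated time of 72 h; on this read-out lower numbers stand for stronger inhibition and higher numbers for weaker inhibition. Compound 1 `COc1ccc(C)cc1NC(=S)N/N=C/c1ccc2ccccc2n1` gives only a limit of the assay, > 100000 nM. Compound 2 `Fc1cccc(NC(=S)N/N=C/c2ccc3ccccc3n2)c1` gives 70100 nM. Compound 3 `Cc1ccccc1NC(=S)N/N=C/c1ccc2ccccc2n1` likewise gives only a limit, > 100000 nM. So compound 3 stands at the limit of > 100000 nM in this assay, at which 2 of the 3 values shown sit, without a number of its own. Among the compounds with values here, the single measured step that reaches compound 3, an at least 1.4-fold higher number from compound 2 to compound 3 (0.15 log units; that floor lies within the scatter), is itself only a floor and lies within the scatter, so it says little about direction or size.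

The unmeasured compound 4 `Cc1cccc(NC(=S)N/N=C/c2ccc3ccccc3n2)c1` differs from compound 3 by 3-methylphenyl in place of 2-methylphenyl on an amide-type nitrogen. No measured step replaces one methylphenyl by another, so nothing shown tells how such a swap moves the read-out. Compound 4 is expected to sit close to where compound 3 sits, with a change of a number no higher from compound 3 to compound 4 (the limit leaves the size open) that is estimated to stay within the scatter. The estimate for compound 4 in this assay is 100000 nM, within 40000 nM to 300000 nM, and it is likely that this assay again reports only a limit.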

Compound 4, half-maximal inhibitory concentration: > 100000 nM
Compound 4: only a limit was reported; the forecaster's own chance of this, stated with the estimate: 60%; the middle value sits exactly at the limit.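

With 3-methylphenyl in place of 2-methylphenyl on the amide-type nitrogen, this assay still gives no number for compound 4, so neither the step from compound 3 nor the step from compound 1 can be read. Within the data shown here, the one readable step, with methyl in place of fluoro on an aromatic carbon, is an at least 1.4-fold higher number from compound 2 to compound 4 (0.15 log units; that floor lies within the scatter), so even this pair gives no firm order. What is new is that the methylphenyl compound with the group in this other place also ends at the limit, and the limit now holds most of the series: the limit of > 100000 nM in this assay, at which 3 of the 4 values shown sit.

Going by these compounds, how far compound 1, compound 3 and compound 4 truly differ from one another remains open, since none has a number of its own. Also open, on these data alone, is whether an amine or a carboxylic acid on the phenyl ring in place of the methyl would give a value clearly apart from these.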